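Replacing methoxy with hydrogen: cytotoxicity notes on compound 3

A few compounds are considered here, and "the series" means these few. Any claim that something is new, unique, unknown or untested is made for them only; others in the source may bear on it.

In an ADME assay on Vero cells (Chlorocebus sabaeus) for cytotoxicity, read by MTT assay, with a stated time of 72 h (on this read-out higher numbers stand for lower toxicity in this test and lower numbers for higher toxicity in this test), compound 1 `COc1cccc([C@@H](O)COC(=O)/C=C/c2ccccc2)c1` gives 22300 nM and compound 2 `COc1ccc([C@@H](O)COC(=O)/C=C/c2ccccc2)cc1` gives 23300 nM as its half-maximal cytotoxic concentration, so compound 2 stands level with compound 1 within the scatter. Compound 3 `O=C(/C=C/c1ccccc1)OC[C@H](O)c1ccccc1` differs from compound 2 by hydrogen in place of methoxy on an aromatic carbon in one place: hydrogen in place of methoxy on an aromatic carbon. Among the measured compounds shown here, no measured pair shows this change, so the expectation is for no step beyond the scatter in this assay for it. The estimate amounts to a 1.1-fold higher number from compound 2 to compound 3 (0.03 log units; within the scatter) as the expected step. For compound 3 the expected value is 25000 nM within an estimated range from 12000 nM to 50000 nM on this read-out.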

Compound 3, half-maximal cytotoxic concentration: 30300 nM
Compound 3: middle estimate off by 1.2-fold (0.08 log units), on the low side; measured number inside the range.
By their numbers in this assay, from the lowest: compounds 1, 2 and 3 (each within the scatter of the next).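

In this assay, hydrogen in place of methoxy on the aromatic carbon para to a large group gives (a 1.3-fold higher number from compound 2 to compound 3 (0.11 log units; within the scatter)), and the same replacement from compound 1 gives (a 1.4-fold higher number from compound 1 to compound 3 (0.13 log units; within the scatter)). Among the compounds shown here, both steps lie within the scatter, so the series so far shows the half-maximal cytotoxic concentration staying level with or without methoxy on this ring. No further data bear on the reason for this. Still open, on these data alone, is whether an amine or a carboxylic acid on this aromatic carbon would also leave the number level.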